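The source may report more compounds than this note shows. Statements on the series, on what has been measured and on what is new or still open speak of the compounds shown alone.

Measured compounds:
compound 1 `O=C(Nc1cccc(-n2cc(-c3ccncc3)c(-c3ccc(Cl)c(O)c3)n2)c1)Nc1cccc(C(F)(F)F)c1` — in a functional assay on UACC-62 cells (Homo sapiens) for inhibition, read by sulforhodamine B assay, with a stated time of 48 h (a lower number here means a stronger inhibitor of growth, a higher number a weaker inhibitor of growth), compound 1 gives 1650 nM
compound 2 `COc1cc(-c2nn(-c3cccc(NC(=O)Nc4cccc(C(F)(F)F)c4)c3)cc2-c2ccncc2)ccc1Cl` — in this assay compound 2 gives 725 nM

Among the measured compounds shown here, compound 2 holds the lower of the two numbers in this assay; the only measured step is a 2.3-fold lower number from compound 1 to compound 2 (0.36 log units; beyond the scatter), a change on the chlorophenyl side of the core.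

Compound 3 `COc1cc(-c2nn(-c3cccc(NC(=O)Nc4ccc(Cl)c(C(F)(F)F)c4)c3)cc2-c2ccncc2)ccc1Cl` differs from compound 2 by chloro in place of hydrogen on an aromatic carbon. For the measured compounds named here, no measured step touches that ring, so the one step measured gives no direct guide. With nothing to point either way, the expected step in this assay is a 1.1-fold lower number from compound 2 to compound 3 (0.05 log units; within the scatter), within the scatter. Compound 3 is therefore estimated at 650 nM, range 250 nM to 1700 nM.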

Compound 3, concentration for 50% growth inhibition: 737 nM
Estimate against measurement, compound 3: 1.1-fold (0.05 log units) below; low and high end bracket the measured number.
By their numbers in this assay, from the lowest: compounds 2 and 3 (each within the scatter of the next); then compound 1.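

Chloro in place of hydrogen, ortho to the trifluoromethyl group, is the only measured change on this ring. In this assay it gives a 1.0-fold higher number from compound 2 to compound 3 (0.01 log units; within the scatter), so 3-(trifluoromethyl)phenyl and 4-chloro-3-(trifluoromethyl)phenyl cannot be told apart here, and this position accepts a chlorine without a loss of growth inhibition. No available data bear on the reason for this result.

Still open, going by these compounds, is how an amine or a carboxylic acid at this position would read in this assay.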